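Working notes on a small antiproliferative series

The compounds below may be only part of what the source reports. "The series", "measured", "known", "first", "only" and "open" are said of these compounds alone.

Three compounds have been measured in a functional assay on MCF7 cells (Homo sapiens) for antiproliferative activity, read by MTT assay, with a stated time of 48 h; on this read-out lower numbers stand for stronger inhibition and higher numbers for weaker inhibition:

compound 1 `COc1ccc2[nH]c(-c3cn(-c4ccccc4)nc3-c3ccccc3)nc2c1` gives 1590 nM
compound 2 `FC(F)(F)c1ccc2[nH]c(-c3cn(-c4ccccc4)nc3-c3ccccc3)nc2c1` gives 2660 nM
compound 3 `COc1ccc2[nH]c(-c3cn(-c4ccccc4)nc3-c3ccc(Cl)cc3)nc2c1` gives 1760 nM

Compound 1 and compound 2 differ by trifluoromethyl in place of methoxy on an aromatic carbon, and that change produced a 1.7-fold higher number from compound 1 to compound 2 (0.22 log units; within the scatter). Compound 1 and compound 3 differ by chloro in place of hydrogen on an aromatic carbon, which is also how the core of compound 3 differs from the core of compound 1; this change produced a 1.1-fold higher number from compound 1 to compound 3 (0.04 log units; within the scatter). All three numbers sit close together, and none of the compounds can be singled out as stronger or weaker than another on this evidence.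

Compound 4 `FC(F)(F)c1ccc2[nH]c(-c3cn(-c4ccccc4)nc3-c3ccc(Cl)cc3)nc2c1` has not yet been measured. It differs from compound 3 by trifluoromethyl in place of methoxy on an aromatic carbon, the same change as from compound 1 to compound 2, with the place described in identical words, so this is the same change made on the chloro-bearing core; it occurs twice among the four compounds. Going by the values given here, the expectation for the step from compound 3 to compound 4 in this assay is a 1.7-fold higher number from compound 3 to compound 4 (0.23 log units; within the scatter), because a 1.7-fold higher number from compound 1 to compound 2 (0.22 log units; within the scatter) is the only earlier guide here. Compound 4 is expected to give about 3000 nM, with a plausible range from 1500 nM to 6000 nM.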

Compound 4, half-maximal inhibitory concentration: 4210 nM
The estimate for compound 4 lay 1.4-fold (0.15 log units) below the measured number; the range from low to high includes it.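

In this assay, trifluoromethyl in place of methoxy on the chloro-bearing core gives a 2.4-fold higher number from compound 3 to compound 4 (0.38 log units; beyond the scatter), and this step does not differ from its counterpart on the core of compound 1: the same change on two cores in this assay, a 1.7-fold higher number (0.22 log units; within the scatter) from compound 1 to compound 2 and a 2.4-fold higher number (0.38 log units; beyond the scatter) from compound 3 to compound 4, 1.4-fold (0.16 log units) apart, within the scatter of two such steps

Chloro in place of hydrogen gives a 1.6-fold higher number from compound 2 to compound 4 (0.20 log units; within the scatter), which likewise matches its earlier counterpart: the same change on two cores in this assay, a 1.1-fold higher number (0.04 log units; within the scatter) from compound 1 to compound 3 and a 1.6-fold higher number (0.20 log units; within the scatter) from compound 2 to compound 4, 1.4-fold (0.16 log units) apart, within the scatter of two such steps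

Going by these compounds alone, both changes therefore carry over between these two cores without a detectable difference, although only the step to compound 4 from compound 3 lies beyond the scatter, and it is modest; with a single pair of cores and one reading per step, this does not show that either change would behave the same way on any other core.

The compounds shown leave open whether the trifluoromethyl step would hold if an amine or a carboxylic acid stood in place of chloro. Also open, from the compounds shown here alone, is what a longer chain in place of methoxy would do on the shared core.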